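Same Small Change, Second Core: An Estimate for Compound 4

This account rests on a few compounds, and the source may have more. Where it says the series, first, only, none or still open, it means among the compounds named here.

Two measured compounds share one core. In a functional assay on PC-3 cells (Homo sapiens) for inhibition, read by sulforhodamine B assay, with a stated time of 48 h, tested at 10 uM (on this read-out higher numbers stand for a weaker effect at the one concentration tested and lower numbers for a stronger effect), compound 1 `O=C(Nc1cccc(-n2cc(-c3ccncc3)c(-c3cc(O)cc(Cl)c3)n2)c1)Nc1ccc(Cl)c(Cl)c1` gives -1.66%, and compound 2 `COc1cc(Cl)cc(-c2nn(-c3cccc(NC(=O)Nc4ccc(Cl)c(Cl)c4)c3)cc2-c2ccncc2)c1` gives -5.03% in this assay. They differ in a single place, (methyl in place of hydrogen on an oxygen on an aromatic ring), and that change made a step of a number 3.4 percentage points lower from compound 1 to compound 2 (within the scatter). Compound 3 `O=C(Nc1cccc(-n2cc(-c3ccncc3)c(-c3cc(O)cc(Cl)c3)n2)c1)c1cc(C(F)(F)F)cc(C(F)(F)F)c1` belongs to a second core; the difference between the two cores is not broken down here. In this assay compound 3 gives 21.7%, the highest of the three numbers and beyond the scatter from both compound 1 and compound 2. Compound 4 `COc1cc(Cl)cc(-c2nn(-c3cccc(NC(=O)c4cc(C(F)(F)F)cc(C(F)(F)F)c4)c3)cc2-c2ccncc2)c1` has not yet been measured. It differs from compound 3 by methyl in place of hydrogen on an oxygen on an aromatic ring, the same change as between compound 1 and compound 2, at a place described in the same words. The earlier step was a number 3.4 percentage points lower from compound 1 to compound 2 (within the scatter), and this change occurs twice among the compounds shown. On that ground the step expected for compound 4 is a number 2.7 percentage points lower from compound 3 to compound 4 (within the scatter), small and within the scatter. Compound 4 is therefore estimated at 19%, with a likely range from 5% to 33%.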

Compound 4, a percentage reported as activity, at one concentration (the size of the read-out at that concentration, not a potency): 35.6%
Compound 4: middle estimate off by 16.6 percentage points, on the low side, outside the stated range (above it).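

Once measured, the change from hydroxy to methoxy on the 3-chloro-5-hydroxyphenyl group did not behave alike on the two cores in this assay: on the second core it gave a number 13.9 percentage points higher from compound 3 to compound 4 (beyond the scatter), which on this read-out means a weaker effect at the one concentration tested. Set side by side, the two steps differ: the same change on two cores in this assay, a number 3.4 percentage points lower (within the scatter) from compound 1 to compound 2 and a number 13.9 percentage points higher (beyond the scatter) from compound 3 to compound 4, 17.3 percentage points apart, beyond the scatter of two such steps. In this series, then, the step seen on one core did not carry over to the other, but two pairs at a single concentration do not show which feature of the cores goes with the difference, or how the change would run on any further core.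

The compounds shown leave open what other groups on that oxygen would give, such as an ethyl group or a longer chain, and what an amine in place of the hydroxy group would give. They also leave open whether the same gap between the two steps would appear across a full concentration series.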